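Turning to a 2-methylphenyl on the amine nitrogen

The compounds below may be only part of what the source reports. "The series", "measured", "known", "first", "only" and "open" are said of these compounds alone.

Measured so far:
compound 1, `CCOc1ccccc1NCn1nc(-c2ccc3c(c2)OCCO3)oc1=S`, 5280 nM
compound 2, `Fc1cccc(F)c1NCn1nc(-c2ccc3c(c2)OCCO3)oc1=S`, 3320 nM
compound 3, `FC(F)(F)c1ccccc1NCn1nc(-c2ccc3c(c2)OCCO3)oc1=S`, 9220 nM

All three were tested in a functional assay, with a stated time of 6 min; on this read-out higher numbers stand for weaker inhibition and lower numbers for stronger inhibition. Compound 2 gives the lowest number of the three; compound 1 stands nearest to it, within the scatter, while compound 3 lies beyond the scatter from compound 2. The two measured steps both run through compound 1: a 1.6-fold lower number from compound 1 to compound 2 (0.20 log units; within the scatter) and a 1.7-fold higher number from compound 1 to compound 3 (0.24 log units; within the scatter), neither of them beyond the scatter.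

The next compound is compound 4, `Cc1ccccc1NCn1nc(-c2ccc3c(c2)OCCO3)oc1=S`. It differs from compound 2 in one place: 2-methylphenyl in place of 2,6-difluorophenyl on an amine nitrogen.

Among the measured compounds shown here, no measured step replaces a 2,6-difluorophenyl with a 2-methylphenyl, so the two steps from compound 1 bear on it only indirectly, as a sign that swaps of the group on the amine nitrogen have so far moved this assay little. With nothing stronger to go on, a small step, if any, is expected for a 1.5-fold higher number from compound 2 to compound 4 (0.18 log units; within the scatter), with no direction preferred and nothing beyond the scatter. The expected value for compound 4 is 5000 nM, in a range from 2000 nM to 12500 nM.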

Compound 4, half-maximal inhibitory concentration: 3450 nM
Estimate against measurement, compound 4: 1.4-fold (0.16 log units) above; measured number inside the range.
By their numbers in this assay, from the lowest: compounds 2, 4, 1 and 3 (each within the scatter of the next, the first and the last beyond it).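

In this assay, 2-methylphenyl on the amine nitrogen cannot be told apart from 2,6-difluorophenyl (a 1.0-fold higher number from compound 2 to compound 4 (0.02 log units; within the scatter)), and methyl in place of ethoxy on an aromatic carbon also stays inside the scatter (a 1.5-fold lower number from compound 1 to compound 4 (0.18 log units; within the scatter)). Among the compounds shown here, the new information is the first single-place step through this group that passes the scatter: methyl in place of trifluoromethyl on an aromatic carbon gives a modest change (a 2.7-fold lower number from compound 3 to compound 4 (0.43 log units; beyond the scatter)), whereas ethoxy to trifluoromethyl at that carbon did not clear the scatter (a 1.7-fold higher number from compound 1 to compound 3 (0.24 log units; within the scatter)), so the group can shift this read-out, though only slightly across these four compounds. Nothing available explains why methyl and trifluoromethyl part in this way.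

The compounds shown leave open whether a plain phenyl, a carboxylic acid, an amine or a longer chain such as propoxy on the aromatic ring would move the number further, in either direction. All four compounds share the same core, so they also leave open how much a change elsewhere in the core would alter the number compared with these swaps on the amine nitrogen.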